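Trimming One Methoxy Group: An Expected Loss of Cell Growth

The compounds below may be only part of what the source reports. "The series", "measured", "known", "first", "only" and "open" are said of these compounds alone.

Of the compounds shown here, three have so far been tested in a functional assay on TK-10 cells (Homo sapiens) for cytotoxicity, read by sulforhodamine B assay, with a stated time of 48 h, tested at 1 uM; on this read-out lower numbers stand for a stronger effect and higher numbers for a weaker effect at the one concentration tested. Compound 1 `COc1ccc(-c2cc(/C=C/C(=O)c3ccc(N)cc3)[nH]n2)cc1` gives 81%, compound 2 `COc1ccc(-c2cc(/C=C/C(=O)c3ccc(N)cc3)[nH]n2)cc1OC` gives 107%, and compound 3 `COc1cc(C(=O)/C=C/c2cc(-c3cc(OC)c(OC)c(OC)c3)n[nH]2)cc(OC)c1OC` gives 80%. Compound 1 differs from compound 2 by hydrogen in place of methoxy on an aromatic carbon, and that step is a number 26 percentage points lower from compound 2 to compound 1 (beyond the scatter). How the core of compound 3 differs from that of compound 2 is not broken down here.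

Compound 4 `COc1ccc(-c2cc(/C=C/C(=O)c3cc(OC)c(OC)c(OC)c3)[nH]n2)cc1OC` awaits measurement and differs from compound 3 by hydrogen in place of methoxy on an aromatic carbon. The surroundings are not identical: in compound 3 the carbon is also meta to a methoxy group, so this is the same kind of change rather than the same one. Because a number 26 percentage points lower from compound 2 to compound 1 (beyond the scatter) rests on a single pair in different surroundings, the step from compound 3 to compound 4 in this assay is expected to be a number 15 percentage points lower from compound 3 to compound 4 (beyond the scatter). Compound 4 is therefore estimated to give 65%, between 45% and 90%.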

Compound 4, a percentage reported as activity, at one concentration (the size of the read-out at that concentration, not a potency): 96%
The estimate for compound 4 lay 31 percentage points below the measured number; the whole stated range lies below it.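

In this assay the replacement of methoxy by hydrogen on an aromatic carbon gave a number 16 percentage points higher from compound 3 to compound 4 (beyond the scatter). Set beside the earlier pair, the same change went in the opposite direction: the same change on two cores in this assay, a number 26 percentage points lower (beyond the scatter) from compound 2 to compound 1 and a number 16 percentage points higher (beyond the scatter) from compound 3 to compound 4, 42 percentage points apart, beyond the scatter of two such steps The size and direction of this change therefore cannot be carried from one core to another in this series, although two pairs do not show which difference between the cores sets the outcome.

The compounds shown leave open how a hydroxyl group or an ethoxy group on that aromatic carbon would compare with methoxy and hydrogen. They also leave open which direction the change would take on a further core.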